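The source may hold more compounds than are shown below. What is called first, only, known or untested is meant among the compounds shown, and "the series" means these compounds.

Measured so far:
- compound 1, `CC(C)(C)CNC(=O)c1ccc(C#Cc2cccc(F)c2)cn1`: in an ADME assay on HEK293 cells for agonist activity at metabotropic glutamate receptor 5 (Rattus norvegicus), read by fluorescence and calcium flux (on this read-out higher numbers stand for larger maximal responses and lower numbers for smaller maximal responses), compound 1 gives 9.5%
- compound 2, `CC(C)(O)CNC(=O)c1ccc(C#Cc2cccc(F)c2)cn1`: in this assay compound 2 gives 20%

Compound 2 holds the highest of the two numbers; its nearest neighbour is compound 1, a step of a number 10.5 percentage points higher from compound 1 to compound 2 (beyond the scatter), beyond the scatter. Compound 3, `CC1(CCNC(=O)c2ccc(C#Cc3cccc(F)c3)cn2)COC1`, has not been measured. It differs from compound 2 as follows: (3-methyloxetan-3-yl)methyl in place of 1-hydroxy-1-methylethyl on a saturated chain carbon bound to an amide-type nitrogen. Among the measured compounds shown here, the only measured step that bears on this change is a number 10.5 percentage points higher from compound 1 to compound 2 (beyond the scatter), in which a hydroxy group entered on the chain; in compound 3 that hydrogen-bond donor is lost again, while a ring-bound acceptor enters. Nothing measured shows what the oxetane ring itself does. For the measured compounds named here, on the strength of the one step, the expectation is a downward step of about a number 8 percentage points lower from compound 2 to compound 3 (within the scatter) in this assay, back toward the level of compound 1. Compound 3 is therefore estimated at 12% in this assay, with a range from 2% to 28%.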

Compound 3, largest response reached (reported as efficacy), in percent of the reference or control that the assay uses: 16.3%
Compound 3: the middle estimate sits 4.3 percentage points below what was measured, within the range that was stated.
By their numbers in this assay, from the lowest: compounds 1, 3 and 2 (each within the scatter of the next, the first and the last beyond it).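

Replacing 1-hydroxy-1-methylethyl with (3-methyloxetan-3-yl)methyl on the saturated chain carbon bound to an amide-type nitrogen gives a number 3.7 percentage points lower from compound 2 to compound 3 (within the scatter) in this assay, so removing the hydrogen-bond donor in this change does not separate compound 3 from compound 2. Replacing tert-butyl with the same group gives a number 6.8 percentage points higher from compound 1 to compound 3 (within the scatter), which means that compound 3 also cannot be separated from compound 1, although compound 1 and compound 2 lie beyond the scatter of each other. No measurement shown here accounts for these numbers.

In compound 3, the four-membered ring and the added heavy atoms enter together, and the compounds shown do not separate the two changes. Also open, going by these compounds, is how an amine or a carboxylic acid at this place would read in this assay.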